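The source may report more compounds than this note shows. Statements on the series, on what has been measured and on what is new or still open speak of the compounds shown alone.

Compound 1 `CCCCCCCCCCCCCCC(N)CO` is the weaker of the two measured compounds in a functional assay on Jurkat cells (Homo sapiens) for inhibition (a lower number here means a stronger inhibitor, a higher number a weaker inhibitor), where compound 1 gives 7000 nM. Going by the values given here, its only measured neighbour, compound 2 `CCCCCCCCCCCCCCC(N)COCc1ccccc1`, gives 3000 nM in this assay, and the step from the one to the other, a 2.3-fold lower number from compound 1 to compound 2 (0.37 log units; beyond the scatter), is the single measured change available. Compound 3 `CCCCCCCCCCCCCCC(CO)N(CC)CC` has not yet been measured; it differs from compound 1 by diethylamino in place of amino on a saturated chain carbon bound to two saturated chain carbons. Among the compounds with values here, no measured step touches that nitrogen, since the one known step concerns the oxygen, so there is no direct precedent to lean on. The benzyl step shows that a sizeable addition at the polar end of this scaffold is tolerated, but that is all it shows. The expectation for compound 3 is therefore a step of no change at the digits printed from compound 1 to compound 3 (within the scatter), with the number for compound 3 estimated at 7000 nM, most likely between 2000 nM and 25000 nM.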

Compound 3, half-maximal inhibitory concentration: 1000 nM
Beside the measured number, compound 3's estimate is 7.0-fold (0.85 log units) above it; the whole stated range lies above it.
By their numbers in this assay, from the lowest: compound 3; then compound 2; then compound 1.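

The nitrogen, untouched by the earlier step on the oxygen, proves open to change in this assay: diethylamino in place of amino on a saturated chain carbon bound to two saturated chain carbons gives a 7.0-fold lower number from compound 1 to compound 3 (0.85 log units; beyond the scatter). The unsubstituted amino group is therefore not needed for inhibition in this series, since the change goes from 1 hydrogen-bond donor to 0 hydrogen-bond donors with the number falling rather than rising. Nothing available here accounts for the size of this step.

As far as these compounds go, it remains open whether a smaller group such as ethylamino or dimethylamino, or a ring such as piperidine on the same nitrogen, would give a similar step. Also open, from the compounds shown here alone, is how diethylamino would behave alongside a benzyl group on the oxygen of the shared core.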